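This account rests on a few compounds, and the source may have more. Where it says the series, first, only, none or still open, it means among the compounds named here.

Compound 3 `CCC1=C(C(=O)CC2CCCC2)[C@H](c2ccc(O)c(Cl)c2)NC(=O)N1` carries cyclopentyl on a saturated chain carbon bound to a carbonyl carbon. In an ADME assay on cells (Homo sapiens) for cytotoxicity (a lower number here means that less compound is tolerated, a higher number that more compound is tolerated), compound 3 gives only the limit > 10000 nM and no number. Compound 1 `CCC1=C(C(=O)CCC2CCCC2)[C@H](c2ccc(O)c(Cl)c2)NC(=O)N1` likewise returns the limit > 10000 nM in this assay. Compound 2 `CCC1=C(C(=O)CCc2ccccc2)[C@H](c2ccc(O)c(Cl)c2)NC(=O)N1` also sits at the limit > 10000 nM in this assay. All three share (the limit of > 10000 nM in this assay, at which 3 of the 3 values shown sit), so the steps a step that the two limits leave unreadable from compound 1 to compound 3 and a step that the two limits leave unreadable from compound 2 to compound 3 at the same position cannot be sized. Compound 4 `CCC1=C(C(=O)CC2CCC(OC)CC2)[C@H](c2ccc(O)c(Cl)c2)NC(=O)N1` differs from compound 3 by 4-methoxycyclohexyl in place of cyclopentyl on a saturated chain carbon bound to a carbonyl carbon. Since no change at this place has moved the read-out off the limit, the expected step is a step that the limit leaves unreadable from compound 3 to compound 4 and lies within the scatter. Compound 4 is estimated at 15000 nM with a range from 7000 nM to 40000 nM and will most likely again be reported as a limit.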

Compound 4, half-maximal cytotoxic concentration: > 10000 nM
Compound 4 ended at the assay's limit; the forecaster's own chance of this, stated with the estimate: 85%; the middle value does not contradict the limit.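

No step can be read among compound 1, compound 2, compound 3 and compound 4 in this assay, because all four end at the same limit: the limit of > 10000 nM in this assay, at which 4 of the 4 values shown sit.

The compounds shown leave open whether any change at this place would yield a number rather than a limit.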